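The compounds below may be only part of what the source reports. "The series", "measured", "known", "first", "only" and "open" are said of these compounds alone.

Three compounds have been measured in an assay on mitochondria from L6 cells (Rattus norvegicus) for activation, with a stated time of 90 min; a higher number here means that more compound is needed for the effect, a lower number that less compound is needed:

Compound 1 `Fc1cccc(Nc2nc3nonc3nc2Nc2ccccc2F)c1` gives 190 nM in this assay.
Compound 2 `Oc1nc2nonc2nc1Nc1cccc(OCc2ccc(C(F)(F)F)cc2)c1` gives 3000 nM in this assay.
Compound 3 `Oc1nc2nonc2nc1Nc1cccc(S(F)(F)(F)(F)F)c1` gives 3700 nM in this assay.

Compound 3 stands at the highest number of the three, meaning it needs the most compound for the effect. Its value and that of compound 2 lie within the usual scatter of each other, so no order can be read between them. Compound 1, with a different pattern of groups on the shared core, gives a far lower number, a gap well beyond the scatter.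

Compound 4 `CCc1cccc(Nc2nc3nonc3nc2O)c1` has not yet been measured. Compared with compound 3 it carries a group of 2 heavy atoms (2 carbon; no ring) in place of a group of 6 heavy atoms (5 fluorine, 1 sulfur; no ring), on an aromatic carbon. Among the measured compounds shown here, no measured pair shows this change directly, so its size in this assay can only be guessed. Compound 2 and compound 3 differ much in their outer groups yet give numbers within the scatter, which points to a small step, in either direction or none beyond the scatter. Compound 4 is therefore expected to give about 4500 nM, within a range of 1500 nM to 14000 nM. This estimate means an expected step of a 1.2-fold higher number from compound 3 to compound 4 (0.09 log units; within the scatter).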

Compound 4, half-maximal effective concentration: 25200 nM
The estimate for compound 4 lay 5.6-fold (0.75 log units) below the measured number; the whole stated range lies below it.
By their numbers in this assay, from the lowest: compound 1; then compounds 2 and 3 (each within the scatter of the next); then compound 4.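

In this assay, putting ethyl in place of the group of five fluorine atoms and one sulfur atom, on an aromatic carbon of the six-membered ring, brings a 6.8-fold higher number from compound 3 to compound 4 (0.83 log units; beyond the scatter) and so lies beyond the scatter. This shows that the group at this position can matter: here, the ethyl compound needs more compound for the effect. No measurement shown here gives a reason for this step.

From the compounds shown here alone, a single step cannot separate the size of a group from its other features, so it remains open where a methyl, a longer chain such as propyl, or an amine at this position would fall. Going by these compounds, it is also open whether the same change would give a similar step on a compound with the pattern of groups seen in compound 1.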